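Lengthening a Side Chain in a Rotarod Series

A few compounds are considered here, and "the series" means these few. Any claim that something is new, unique, unknown or untested is made for them only; others in the source may bear on it.

Measured compounds:
Compound 1 `NC(C(=O)NCC(=O)Nc1ccc(Cl)cc1C(=O)c1ccccc1)c1ccccc1` — > 100 mg/kg
Compound 2 `CCCC(=O)NCC(=O)N(C)c1ccc(Cl)cc1C(=O)c1ccccc1Cl` — 55.2 mg/kg
Compound 3 `CC(=O)NCC(=O)Nc1ccc(Cl)cc1C(=O)c1ccccc1` — > 100 mg/kg

In a functional assay on the whole organism with Mus musculus as the target, in the rotarod test (on this read-out higher numbers stand for an effect only at larger amounts of compound and lower numbers for an effect already at smaller amounts), compound 2 gives 55.2 mg/kg. The value of compound 1 in this assay is a limit, > 100 mg/kg. The value of compound 3 is also a limit, > 100 mg/kg. Among the compounds with values here, compound 2 is thus the only compound with a real number; the other two sit at the limit of > 100 mg/kg in this assay, at which 2 of the 3 values shown sit. Within the data shown here, the single measured step, a step that the two limits leave unreadable from compound 1 to compound 3, has no readable size, as both of its ends are limits.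

Compound 4 `CCCCC(=O)NCC(=O)N(C)c1ccc(Cl)cc1C(=O)c1ccccc1Cl` differs from compound 2 by methyl in place of hydrogen on a saturated chain carbon, three bonds along the chain from a carbonyl carbon. Among the measured compounds shown here, no measured step concerns a change of this kind, so nothing among the known values supports a move in either direction beyond the usual scatter. Compound 4 is therefore expected to give 55 mg/kg, with a range from 25 mg/kg to 120 mg/kg. This estimate corresponds to a step of a 1.0-fold lower number from compound 2 to compound 4 (0.00 log units; within the scatter), which is expected to stay within the scatter.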

Compound 4, dose for half-maximal effect: 90 mg/kg
Beside the measured number, compound 4's estimate is 1.6-fold (0.21 log units) below it; the measured number falls inside the stated range.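

Within the data shown here, this is the first step whose size can be read, since compound 2 and compound 4 both give real numbers in this assay. Putting methyl in place of hydrogen at this position, which turns propyl into butyl, gives a 1.6-fold higher number from compound 2 to compound 4 (0.21 log units; within the scatter), so this change at this place leaves the read-out within the usual scatter. Compound 4 thus keeps a real number, while the other values remain limits: the limit of > 100 mg/kg in this assay, at which 2 of the 4 values shown sit.

One step cannot show how far the chain can be extended or altered, and a pentyl chain, or an amine or a carboxylic acid at its end, might read differently. Going by these compounds, compound 2 and compound 3 differ in more than one place, so which of those differences matters stays open.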